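Removing the methyl from the sulfur of compound 3

This account rests on a few compounds, and the source may have more. Where it says the series, first, only, none or still open, it means among the compounds named here.

Measured in an ADME assay on 184B5 cells (Homo sapiens) for cytotoxicity, read by MTT assay, with a stated time of 72 h; a higher number here means a weaker inhibitor of growth, a lower number a stronger inhibitor of growth:
compound 1, `COc1ccc(CNc2nc([Se]C)nc3ccccc23)cc1`, gives > 100000 nM, a limit of the assay.
compound 2, `Sc1nc(NCc2ccccc2)c2ccccc2n1`, gives > 100000 nM, a limit of the assay.
compound 3, `COc1ccc(CNc2nc(SC)nc3ccccc23)cc1`, gives > 100000 nM, a limit of the assay.

Compound 3 thus stands only at the limit. All three values sit at the limit of > 100000 nM in this assay, at which 3 of the 3 values shown sit. Among the measured compounds shown here, the one counted step, a step that the two limits leave unreadable from compound 1 to compound 3, runs between two limits and its size cannot be read. Compound 4, `COc1ccc(CNc2nc(S)nc3ccccc23)cc1`, differs from compound 3 by hydrogen in place of methyl on a sulfur. Compound 2 carries the same sulfanyl group on the shared core and also reaches only the limit. For the measured compounds named here, no measured step bears readably on this change, so no shift beyond the scatter is expected in this assay. The estimated step that the limit leaves unreadable from compound 3 to compound 4 is expected to be negligible. Compound 4 is expected at 150000 nM, within 50000 nM to 500000 nM, most likely reported again as a limit.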

Compound 4, concentration for total growth inhibition: 36600 nM
The estimate for compound 4 lay 4.1-fold (0.61 log units) above the measured number, outside the stated range (below it).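

In this assay, the sulfanyl group gives an at least 2.7-fold lower number from compound 3 to compound 4 (0.43 log units; beyond the scatter), so this position first responds when methylsulfanyl becomes sulfanyl. The sulfanyl group does not suffice alone: methoxy in place of hydrogen on an aromatic carbon gives an at least 2.7-fold lower number from compound 2 to compound 4 (0.43 log units; beyond the scatter). One sulfur atom in place of the selenium-bearing group gives an at least 2.7-fold lower number from compound 1 to compound 4 (0.43 log units; beyond the scatter), so both the sulfanyl and the methoxy groups accompany the first readable number. On these data alone, whether an amine on that aromatic carbon, or a longer chain on the sulfur, would also move the number remains open. The full size of each step also remains open, as each starts from a limit: the limit of > 100000 nM in this assay, at which 3 of the 4 values shown sit.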